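Pyrrolidin-1-yl in place of piperidin-1-yl: series notes

This account rests on a few compounds, and the source may have more. Where it says the series, first, only, none or still open, it means among the compounds named here.

Measured so far in a functional assay on HepG2 cells (Homo sapiens) for antiproliferative activity, read by MTT assay, with a stated time of 72 h; on this read-out higher numbers stand for weaker inhibition and lower numbers for stronger inhibition:
- compound 1 `CN(C)CCn1cccc1/C=N/NC(=O)Nc1ccc(Oc2ccnc3[nH]ccc23)cc1`: "not active" (no number reported)
- compound 2 `O=C(N/N=C/c1cccn1CCCN1CCCCC1)Nc1ccc(Oc2ccnc3[nH]ccc23)cc1`: 3690 nM

For the measured compounds named here, compound 2 holds the only number so far, as compound 1 gave no number. Going by the values given here, no pair of measured compounds differs in one place, so the data offer no measured step to draw on.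

Compound 3 `O=C(N/N=C/c1cccn1CCCN1CCCC1)Nc1ccc(Oc2ccnc3[nH]ccc23)cc1` is still to be measured. It differs from compound 2 as follows: pyrrolidin-1-yl in place of piperidin-1-yl on a saturated chain carbon, three bonds along the chain from an aromatic nitrogen. The change is pyrrolidin-1-yl in place of piperidin-1-yl on a saturated chain carbon, three bonds along the chain from an aromatic nitrogen.

In this assay, among the compounds with values here, no step beyond the scatter is expected, in either direction, and the sole anchor is compound 2 at 3690 nM. The expected change is a 1.1-fold lower number from compound 2 to compound 3 (0.02 log units; within the scatter). The estimated value for compound 3 is 3500 nM, with an expected range of 1400 nM to 8500 nM.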

Compound 3, half-maximal inhibitory concentration: 1420 nM
For compound 3 the middle estimate is 2.5-fold (0.39 log units) above the measured one; measured number inside the range.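

In this assay, the series now has its first measured step: pyrrolidin-1-yl in place of piperidin-1-yl on a saturated chain carbon, three bonds along the chain from an aromatic nitrogen, gives a 2.6-fold lower number from compound 2 to compound 3 (0.41 log units; beyond the scatter). Exchanging one six-membered non-aromatic ring for one five-membered non-aromatic ring, with the same single hetero atom, is therefore enough to move the read-out beyond the usual scatter, although the step is modest and rests on one pair. No measurement at hand bears on what lies behind this step.

For the compounds shown here, compound 1 differs from compound 2 and compound 3 in more than one place, so it adds no step to this comparison. From the compounds shown here alone, whether morpholin-4-yl or azepan-1-yl in place of pyrrolidin-1-yl, or a 4-(pyrrolidin-1-yl)butyl chain in place of 3-(pyrrolidin-1-yl)propyl, would extend or reverse the step remains open.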